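This account rests on a few compounds, and the source may have more. Where it says the series, first, only, none or still open, it means among the compounds named here.

In a functional assay (Homo sapiens) for inhibition (a higher number here means a weaker inhibitor, a lower number a stronger inhibitor), compound 1 (`CSc1ccc(CSc2nc(-c3ccc(Cl)cc3)c(-c3ccncc3)[nH]2)cc1`) gives 2200 nM and compound 2 (`C[S+]([O-])c1ccc(CSc2nc(-c3ccc(Cl)cc3)c(-c3ccncc3)[nH]2)cc1`) gives 320 nM as the lower of the two numbers. Compound 3 (`CS(=O)(=O)c1ccc(CSc2nc(-c3ccc(Cl)cc3)c(-c3ccncc3)[nH]2)cc1`) differs from compound 2 on an aromatic carbon para to a large group, where methylsulfonyl enters: a group of 4 heavy atoms (1 carbon, 2 oxygen, 1 sulfur; no ring) in place of a group of 3 heavy atoms (1 carbon, 1 oxygen, 1 sulfur; no ring), on an aromatic carbon and nothing else changes. Among the compounds with values here, only one measured step bears on this, a 6.9-fold lower number from compound 1 to compound 2 (0.84 log units; beyond the scatter) at that same carbon, modest and beyond the scatter. From that single step, a smaller move in the same direction is expected, possibly none beyond the scatter. For compound 3 the estimate is 250 nM with an expected range from 80 nM to 800 nM in this test. The estimated change is a 1.3-fold lower number from compound 2 to compound 3 (0.11 log units; within the scatter) overall.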

Compound 3, half-maximal inhibitory concentration: 320 nM
For compound 3 the middle estimate is 1.3-fold (0.11 log units) below the measured one, within the range that was stated.
By their numbers in this assay, from the lowest: compounds 2 and 3 (each within the scatter of the next); then compound 1.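

In this assay, methylsulfonyl in place of the group with one oxygen on sulfur brings no change at the digits printed from compound 2 to compound 3 (within the scatter) at this aromatic carbon, so the second oxygen adds no difference that this test can separate. Methylsulfonyl in place of methylsulfanyl brings a 6.9-fold lower number from compound 1 to compound 3 (0.84 log units; beyond the scatter) in this test, the same size as the step to compound 2, so the lower number is kept with either oxidised group. Nothing available explains this flat step. As far as these compounds go, whether an amine or a carboxylic acid on this carbon would go lower remains open. So does the effect of a longer chain on the sulfur.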